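Moving Two Chlorines on a Benzyl Ether, Across Two Cores

A few compounds are considered here, and "the series" means these few. Any claim that something is new, unique, unknown or untested is made for them only; others in the source may bear on it.

Compound 1 `Cc1ccc(NC(=S)NC(=O)c2ccc(OCc3ccc(Cl)c(Cl)c3)cc2)cc1-c1nc2ccccc2[nH]1` and compound 2 `Cc1ccc(NC(=S)NC(=O)c2ccc(OCc3ccc(Cl)cc3Cl)cc2)cc1-c1nc2ccccc2[nH]1` share one core, while compound 3 `Cc1ccc(NC(=O)NC(=O)c2ccc(OCc3ccc(Cl)c(Cl)c3)cc2)cc1-c1nc2ccccc2[nH]1` and compound 4 `Cc1ccc(NC(=O)NC(=O)c2ccc(OCc3ccc(Cl)cc3Cl)cc2)cc1-c1nc2ccccc2[nH]1` share another; the difference between the two cores is not broken down here. In a functional assay on MGC-803 cells (Homo sapiens) for inhibition, read by MTT assay, with a stated time of 48 h (a lower number here means a stronger inhibitor, a higher number a weaker inhibitor), compound 1 gives 6390 nM, and compound 2 gives 3450 nM. The change from compound 1 to compound 2 is 2,4-dichlorophenyl in place of 3,4-dichlorophenyl on a saturated chain carbon bound to an oxygen on an aromatic ring, and it made a step of a 1.9-fold lower number from compound 1 to compound 2 (0.27 log units; within the scatter). Compound 3 in this assay gives 6080 nM, a number close to that of compound 1. Compound 4 carries the same change relative to compound 3: 2,4-dichlorophenyl in place of 3,4-dichlorophenyl on a saturated chain carbon bound to an oxygen on an aromatic ring. Among these four compounds the change occurs twice in all, once with both ends measured and once with only the starting point known.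

For compound 4 the expected step is a 1.7-fold lower number from compound 3 to compound 4 (0.24 log units; within the scatter), because the same change on the first core made the step of a 1.9-fold lower number from compound 1 to compound 2 (0.27 log units; within the scatter). That expectation rests on a single measured pair, and nothing else is known about how the second core answers this change, so the range is kept wide enough to take in no change at all. In this assay compound 4 is estimated at 3500 nM, with a likely span from 1600 nM to 8000 nM.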

Compound 4, half-maximal inhibitory concentration: 2740 nM
Estimate against measurement, compound 4: 1.3-fold (0.11 log units) above, and the stated range covers the measured number.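

In this assay, putting 2,4-dichlorophenyl in place of 3,4-dichlorophenyl on the core of compound 3 gave a 2.2-fold lower number from compound 3 to compound 4 (0.35 log units; beyond the scatter), a modest step. Set beside the same change on the core of compound 1, the new step shows that the change carried from one core to the other with no difference between the two that stands out from the scatter: the same change on two cores in this assay, a 1.9-fold lower number (0.27 log units; within the scatter) from compound 1 to compound 2 and a 2.2-fold lower number (0.35 log units; beyond the scatter) from compound 3 to compound 4, 1.2-fold (0.08 log units) apart, within the scatter of two such steps. Going by these compounds alone, this agreement rests on only two matched pairs in one cell assay, and since only the new step lies beyond the scatter, it does not show a dependable effect of the change on every core, nor does it explain the cause of either step.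

The compounds shown leave open whether the agreement extends to other substituents on the same ring, such as a single chlorine, a trifluoromethyl group or a methoxy group, and whether it would survive on a third core. They also leave open whether the same step would appear in other cell lines, and how much the difference between the two cores contributes on its own.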